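Azetidinyl carbonyl in place of acetyl on a CCR8 sulfonamide

The source may hold more compounds than are shown below. What is called first, only, known or untested is meant among the compounds shown, and "the series" means these compounds.

Compound 1 `CCN(CC)S(=O)(=O)c1ccc(NC(=O)c2ccccc2)c2ccccc12`: > 30000 nM
Compound 2 `CCOC(=O)N1CCC(NS(=O)(=O)c2ccc(O)c3ccccc23)CC1`: > 5000 nM
Compound 3 `CC(=O)N1CCC(NS(=O)(=O)c2ccc(NC(=O)c3ccccc3C)c3ccccc23)CC1`: 6.7 nM

Of the compounds shown here, three have been tested in an assay on L1.2 cells for binding affinity to C-C chemokine receptor type 8 (Homo sapiens); a lower number here means a stronger inhibitor, a higher number a weaker inhibitor. For compound 1 the result is a limit of the assay, > 30000 nM. For compound 2 the result is likewise a limit, > 5000 nM. Compound 3 is the only one of the three with an actual number, 6.7 nM, and so it is the one point from which a step can be taken.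

Compound 4 `Cc1ccccc1C(=O)Nc1ccc(S(=O)(=O)NC2CCN(C(=O)C3CNC3)CC2)c2ccccc12` differs from compound 3 in one place: azetidin-3-yl in place of methyl on a carbonyl carbon. The change sits on the carbonyl carbon of the acetyl group, turning 1-acetylpiperidin-4-yl into 1-((azetidin-3-yl)carbonyl)piperidin-4-yl. For the measured compounds named here, no step between two measured compounds covers a change of this kind, so there is no measured precedent to lean on. The expectation is that the step from compound 3 to compound 4 in this assay stays within the usual scatter, with no clear direction. Compound 4 is expected to give about 5 nM in this assay, with a likely range from 1.5 nM to 20 nM, a step of a 1.3-fold lower number from compound 3 to compound 4 (0.13 log units; within the scatter).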

Compound 4, inhibition constant: 1.5 nM
For compound 4 the middle estimate is 3.3-fold (0.52 log units) above the measured one, within the range that was stated.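

For the compounds shown here, the earlier compounds gave only one actual number, so they showed nothing about how this carbonyl carbon tolerates change. In this assay, putting azetidin-3-yl in place of methyl gives a 4.5-fold lower number from compound 3 to compound 4 (0.65 log units; beyond the scatter), so this position accepts a four-membered ring with a hydrogen-bond donor, and the number improves modestly rather than being lost. The two limits among the earlier compounds do not bear on this step, and nothing shown explains why the number moved.

This single step cannot say whether the gain belongs to the ring, to its nitrogen, or to both. On these data alone, whether an open-chain amine such as aminomethyl, the azetidine nitrogen capped with methyl, or a carbocyclic cyclobutyl would serve equally at this carbonyl carbon stays open.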